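A few compounds are considered here, and "the series" means these few. Any claim that something is new, unique, unknown or untested is made for them only; others in the source may bear on it.

Measured so far in an in vivo ADME assay on the whole organism (strain 129/SvEvBrd x C57BL/6) for pharmacokinetics, with Mus musculus as the target, at a dose of 1 mg/kg by the intravenous route; a higher number here means faster removal of the compound, a lower number slower removal:
- compound 1 `CC(=O)c1nc([C@@H](O)[C@H](O)[C@H](O)CO)c(-c2ccccc2)[nH]1`: 23.9 mL/min/kg
- compound 2 `OC[C@@H](O)[C@@H](O)[C@H](O)c1c[nH]c(C(F)(F)C(F)(F)F)n1`: 1.3 mL/min/kg
- compound 3 `Cc1nc(-c2nc([C@@H](O)[C@H](O)[C@H](O)CO)c[nH]2)cs1`: 19.4 mL/min/kg

Compound 3, at 19.4 mL/min/kg, lies within the scatter of compound 1. Compound 2 lies well beyond the scatter on the low side of compound 3, so the upper pair and compound 2 are clearly separated in this assay. Among the compounds with values here, no two measured compounds differ in only one place, so no measured step bears directly on the next change.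

The next compound is compound 4 `OC[C@@H](O)[C@@H](O)[C@H](O)c1c[nH]c(-c2cnccn2)n1`. It keeps the shared core of compound 3 and carries pyrazin-2-yl in place of 2-methyl-1,3-thiazol-4-yl on an aromatic carbon.

Compound 3 at 19.4 mL/min/kg is the natural anchor for the estimate, as it is the nearest structure. Compound 2 at 1.3 mL/min/kg shows that much lower numbers occur on this core, so the expectation leans slightly downward. The expected move is small and not beyond the scatter: a 1.6-fold lower number from compound 3 to compound 4 (0.21 log units; within the scatter). For compound 4 the estimated clearance is 12 mL/min/kg, with an expected range from 4 mL/min/kg to 30 mL/min/kg.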

Compound 4, clearance: 13.4 mL/min/kg
Compound 4: the middle estimate sits 1.1-fold (0.05 log units) below what was measured; low and high end bracket the measured number.
By their numbers in this assay, from the lowest: compound 2; then compounds 4, 3 and 1 (each within the scatter of the next).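

In this assay, pyrazin-2-yl in place of 2-methyl-1,3-thiazol-4-yl, on the aromatic carbon between two ring nitrogen atoms, gives a 1.4-fold lower number from compound 3 to compound 4 (0.16 log units; within the scatter). Within the data shown here, this is the first comparison that changes one place only, and it shows that at this position a six-membered aromatic ring can stand in for a five-membered aromatic ring without a difference that can be told from the scatter, so these two groups cannot be separated by clearance here. No measurement at hand accounts for this step, so the reason for the result stays unknown.

As far as these compounds go, whether an amine, a carboxylic acid or a longer alkyl chain on this same aromatic carbon would leave the number in the range of compound 3 and compound 4, or bring it toward compound 2 at 1.3 mL/min/kg, remains open. Also open, from the compounds shown here alone, is whether a pyridin-2-yl group at this place would read like pyrazin-2-yl, which would show how far this tolerance extends among aromatic rings.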